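Swapping an Aryl Group: Expected Clearance in Rat Microsomes

The source may hold more compounds than are shown below. What is called first, only, known or untested is meant among the compounds shown, and "the series" means these compounds.

Three compounds share one core and differ only in a single group attached to an aromatic carbon. Compound 1 `Nc1ccc(S(=O)(=O)N2CCN(c3ncc(C(O)(C(F)(F)F)C(F)(F)F)cc3C#CCCO)CC2)cn1`, compound 2 `Nc1ccc(S(=O)(=O)N2CCN(c3ncc(C(O)(C(F)(F)F)C(F)(F)F)cc3-c3ccccc3O)CC2)cn1` and compound 3 `CS(=O)(=O)c1ccc(-c2cc(C(O)(C(F)(F)F)C(F)(F)F)cnc2N2CCN(S(=O)(=O)c3ccc(N)nc3)CC2)cc1` were each run in an ADME assay (liver) for metabolic stability, with Liver microsome (Rattus norvegicus) as the target, using microsomes and NADPH, with a stated time of 30 min, tested at 1 uM; on this read-out higher numbers stand for fast clearance and lower numbers for slow clearance. Compound 1 gives 68 mL.min-1.g-1, compound 2 gives 125 mL.min-1.g-1 and compound 3 gives 103 mL.min-1.g-1. Compound 3 stands close to both neighbours: the step of a 1.2-fold lower number from compound 2 to compound 3 (0.08 log units; within the scatter) and the step of a 1.5-fold higher number from compound 1 to compound 3 (0.18 log units; within the scatter) each stay within the scatter, so the three numbers cannot be told apart.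

Compound 4 `Cc1nc2cc(-c3cc(C(O)(C(F)(F)F)C(F)(F)F)cnc3N3CCN(S(=O)(=O)c4ccc(N)nc4)CC3)ccc2o1` has not yet been measured. Its structure differs from compound 3 in one place: 2-methyl-1,3-benzoxazol-5-yl in place of 4-(methylsulfonyl)phenyl on an aromatic carbon. The measured steps that bear on this change are the swaps of one group for another on that same carbon, a 1.8-fold higher number from compound 1 to compound 2 (0.26 log units; within the scatter), a 1.5-fold higher number from compound 1 to compound 3 (0.18 log units; within the scatter) and a 1.2-fold lower number from compound 2 to compound 3 (0.08 log units; within the scatter), and none of them moved beyond the scatter. A step of similar size, with no clear direction, is therefore expected in this assay, namely a 1.0-fold lower number from compound 3 to compound 4 (0.01 log units; within the scatter). Compound 4 is expected to give about 100 mL.min-1.g-1, within a range from 50 mL.min-1.g-1 to 200 mL.min-1.g-1.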

Compound 4, intrinsic clearance in microsomes: 99 mL.min-1.g-1
Compound 4: the middle estimate sits 1.0-fold (0.00 log units) above what was measured; low and high end bracket the measured number.
By their numbers in this assay, from the lowest: compounds 1, 4, 3 and 2 (each within the scatter of the next).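

Replacing 4-(methylsulfonyl)phenyl with 2-methyl-1,3-benzoxazol-5-yl removes the sulfur and adds a five-membered aromatic ring with 2 hetero atoms, yet in this assay the result is only a 1.0-fold lower number from compound 3 to compound 4 (0.02 log units; within the scatter), which lies within the scatter. The new group also stays within the scatter of the other two groups on this carbon, with a 1.3-fold lower number from compound 2 to compound 4 (0.10 log units; within the scatter) and a 1.5-fold higher number from compound 1 to compound 4 (0.16 log units; within the scatter), so all four groups at this position, including the one with two aromatic rings, cannot be told apart on this read-out. Nothing measured here offers an explanation for this lack of separation.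

From the compounds shown here alone, it remains open whether a group of another kind on this aromatic carbon, such as an amine or a carboxylic acid, would move the clearance beyond the scatter. Going by these compounds, all four compounds also keep the rest of the core unchanged, so the effect of changes elsewhere, such as replacing the 2,2,2-trifluoro-1-hydroxy-1-(trifluoromethyl)ethyl group, remains open too.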